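The source may report more compounds than this note shows. Statements on the series, on what has been measured and on what is new or still open speak of the compounds shown alone.

Compound 1 `O=[N+]([O-])c1cn2c(n1)OC[C@@H](OCc1cccc(-c3ccc(F)cc3)c1)C2`, compound 2 `O=[N+]([O-])c1cn2c(n1)OC[C@@H](OCc1ccc(-c3ccc(C(F)(F)F)cc3)s1)C2` and compound 3 `N#Cc1ccc(-c2ccc(CO[C@@H]3COc4nc([N+](=O)[O-])cn4C3)s2)cc1` share one core and differ only in the outer aromatic group attached to it. In an ADME assay on Vero cells (Chlorocebus sabaeus) for cytotoxicity, with a stated time of 72 h (a higher number here means a weaker inhibitor, a lower number a stronger inhibitor), compound 1 gives > 128000 nM, which is a limit of the assay and not a number. In this assay compound 2 gives > 128000 nM, again a limit. In this assay compound 3 gives > 128000 nM, also a limit. Within the data shown here, the one single-point comparison, a step that the two limits leave unreadable from compound 2 to compound 3, cannot be read because both of its ends sit at the limit of > 128000 nM in this assay, at which 3 of the 3 values shown sit. Compound 3 therefore stands at the same limit as the two other compounds, and no ordering among them can be drawn.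

Compound 4 `COc1ccc(-c2ccc(CO[C@@H]3COc4nc([N+](=O)[O-])cn4C3)s2)cc1F` differs from compound 3 in one place: 3-fluoro-4-methoxyphenyl in place of 4-cyanophenyl on an aromatic carbon. Among the measured compounds shown here, no measured step gives a readable size for a change of this kind, so the only guide is that every compound measured so far, compound 1, compound 2 and compound 3, rests at the limit of > 128000 nM in this assay, at which 3 of the 3 values shown sit. The step of a number no higher from compound 3 to compound 4 (the limit leaves the size open) is therefore expected to show no movement beyond the scatter. Compound 4 is estimated to give 128000 nM in this assay, with a range from 60000 nM to 300000 nM, and most likely to be reported only as a limit.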

Compound 4, half-maximal inhibitory concentration: > 128000 nM
Compound 4 was reported as a limit; the forecaster's own chance of this, stated with the estimate: 85%; the middle value sits exactly at the limit.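

Compound 4 gives > 128000 nM in this assay, which is a limit of the assay and not a number. The change from compound 3 to compound 4 therefore cannot be read, since both ends sit at the same limit: the limit of > 128000 nM in this assay, at which 4 of the 4 values shown sit. The compounds shown leave open what actual value any of them has in this assay, and so whether the outer aromatic group affects it at all.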